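Benzyl Ether Swap on a Diaryloxy Diamine Scaffold

The source may report more compounds than this note shows. Statements on the series, on what has been measured and on what is new or still open speak of the compounds shown alone.

Three compounds were measured in a functional assay on PC-3 cells (Homo sapiens) for cytotoxicity, read by sulforhodamine B assay; a lower number here means a stronger inhibitor of growth, a higher number a weaker inhibitor of growth:

Compound 1, `COc1cccc(OC)c1OCCNCCOc1ccccc1OCc1cccc(Cl)c1`, gives 20400 nM.
Compound 2, `COc1cccc(OC)c1OCCNCCOc1ccccc1OCc1ccccc1[N+](=O)[O-]`, gives 34700 nM.
Compound 3, `COc1cccc(OC)c1OCCNCCOc1ccccc1OCc1cccc([N+](=O)[O-])c1`, gives 38900 nM.

All three share one core and differ only in the group on the saturated chain carbon bound to an oxygen on an aromatic ring. The steps among them are small: a 1.7-fold higher number from compound 1 to compound 2 (0.23 log units; within the scatter), a 1.9-fold higher number from compound 1 to compound 3 (0.28 log units; within the scatter) and a 1.1-fold higher number from compound 2 to compound 3 (0.05 log units; within the scatter). Compound 3 therefore sits alongside compound 1 and compound 2, its distance from each within the scatter, so no order among the three can be read from these numbers.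

Compound 4, `COc1cccc(OC)c1OCCNCCOc1ccccc1OCc1ccc(OC(C)C)cc1`, has not been measured in this assay. It differs from compound 3 as follows: 4-isopropoxyphenyl in place of 3-nitrophenyl on a saturated chain carbon bound to an oxygen on an aromatic ring. Among the compounds with values here, no measured pair shows this exact exchange. The three steps that do exist, all changes of the same group at the same place, stay within the scatter, which gives no ground to expect a move in either direction for compound 4. Compound 4 is thus estimated at 30000 nM, with a range of 12000 nM to 75000 nM. The expected step is a 1.3-fold lower number from compound 3 to compound 4 (0.11 log units; within the scatter).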

Compound 4, concentration for total growth inhibition: 17800 nM
The estimate for compound 4 lay 1.7-fold (0.23 log units) above the measured number; the range from low to high includes it.
By their numbers in this assay, from the lowest: compounds 4, 1, 2 and 3 (each within the scatter of the next, the first and the last beyond it).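

In this assay, within the data shown here, the exchange of 3-nitrobenzyl for 4-isopropoxybenzyl gives the first step at this position to pass the scatter, a 2.2-fold lower number from compound 3 to compound 4 (0.34 log units; beyond the scatter), and it is a modest one. The same group set against the other two compounds stays within the scatter, with a 1.9-fold lower number from compound 2 to compound 4 (0.29 log units; within the scatter) and a 1.1-fold lower number from compound 1 to compound 4 (0.06 log units; within the scatter), so the 4-isopropoxyphenyl group is separated from the 3-nitrophenyl group alone and cannot be placed in any order relative to the 2-nitrophenyl or 3-chlorophenyl groups. The compounds shown offer no independent measurement that could account for the single step beyond the scatter.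

Compound 4 changes both the group on the ring and the place it occupies, so these compounds cannot separate the removal of the 3-nitrophenyl group from the arrival of the 4-isopropoxyphenyl group. They also leave open whether an amine or a carboxylic acid on this aromatic ring, or a longer chain in place of the isopropoxy group, would move the number further from that of compound 3 or leave it within the scatter.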